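The source may hold more compounds than are shown below. What is called first, only, known or untested is meant among the compounds shown, and "the series" means these compounds.

Measured so far:
- compound 1, `O=C(O)[C@H]1NC[C@H](O)[C@H](O)[C@H]1O` — 7.6%
- compound 2, `O=C(O)[C@@H]1NC[C@H](O)[C@@H](O)[C@H]1O` — 42%

Two stereoisomers of one core have been run in an assay on isolated protein for inhibition of cytosolic endo-beta-N-acetylglucosaminidase (Homo sapiens), tested at 1000 uM; a lower number here means less inhibition, a higher number more inhibition at the concentration tested (going by the name of the read-out). Compound 1 gives 7.6%; compound 2 gives 42%, and the step is a number 34.4 percentage points higher from compound 1 to compound 2 (beyond the scatter). Among the compounds with values here, compound 2 thus stands highest of the two numbers, with compound 1 its only neighbour and well below it. The only thing that moves between these two is the fact that compounds 1 and 2 differ only in the configuration as drawn, so configuration alone has been enough to shift the read-out by a large margin within this pair.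

Compound 3, `O=C(O)[C@@H]1NC[C@@H](O)[C@H](O)[C@@H]1O`, is the next isomer to be measured. Relative to compound 2: the two compounds have the same atoms and bonds and differ only in configuration as drawn: 3 of 4 stereo elements differ; a stereocentre at a saturated ring carbon is drawn S in compound 2 and R in compound 3; a stereocentre at a saturated ring carbon is drawn R in compound 2 and S in compound 3; a stereocentre at a saturated ring carbon is drawn S in compound 2 and R in compound 3. Three of the four centres are redrawn, so compound 3 is not a close neighbour of either measured isomer. Within the data shown here, the one step seen, a number 34.4 percentage points higher from compound 1 to compound 2 (beyond the scatter), shows only that reconfiguring two centres can swing this assay by a large amount in either direction. Compound 1 and compound 2 bracket the range seen so far. No direction can be read from two points; a step of substantial size is plausible either way.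

Compound 3 is estimated at 20%, with a range of 3% to 60%, which means an expected step of a number 22 percentage points lower from compound 2 to compound 3 (beyond the scatter).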

Compound 3, a percentage reported as inhibition, at one concentration (the size of the read-out at that concentration, not a potency): 0.8%
Compound 3: middle estimate off by 19.2 percentage points, on the high side; the measured number lies below the stated range.
By their numbers in this assay, from the lowest: compounds 3 and 1 (each within the scatter of the next); then compound 2.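

Redrawing three of the four centres of compound 2 costs most of the inhibition seen in this assay, the step being a number 41.2 percentage points lower from compound 2 to compound 3 (beyond the scatter) and configuration the only thing that changes: the fact that compounds 2 and 3 differ only in the configuration as drawn

Redrawing the same number of centres from compound 1 gives a very different outcome, with the step being a number 6.8 percentage points lower from compound 1 to compound 3 (within the scatter) and again nothing but configuration changing: the fact that compounds 1 and 3 differ only in the configuration as drawn

The number of redrawn centres therefore does not set the size of the step, and compound 2 alone stands apart among the three isomers, with its steps to compound 1 and compound 3 both printed as beyond the scatter.

The pairs shown differ at two or three centres at once, so they do not assign the difference to any single centre. From the compounds shown here alone, it also remains open whether the configuration of compound 2 would give a similar read-out with a primary amide or a hydroxymethyl group in place of the carboxylic acid.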